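Fluoro to nitro on the aromatic carbon of compound 3

The source may report more compounds than this note shows. Statements on the series, on what has been measured and on what is new or still open speak of the compounds shown alone.

Three analogues sharing one core have been run in a functional assay on cells (Splenocyte, Mus musculus, strain BALB/c) for inhibition, read by scintillation counting and thymidine incorporation, with stated times of 48 h and 8 h; a higher number here means a weaker inhibitor, a lower number a stronger inhibitor. Compound 1 `COc1cc(-c2noc(Cc3c[nH]c4ccccc34)n2)cc(OC)c1OC` gives only a limit in this assay, > 50000 nM. Compound 2 `c1ccc(-c2noc(Cc3c[nH]c4ccccc34)n2)cc1` likewise gives only a limit in this assay, > 50000 nM. For the measured compounds named here, compound 3 `Fc1ccc(-c2noc(Cc3c[nH]c4ccccc34)n2)cc1` is the sole member with a number, 5400 nM in this assay. Compound 1 and compound 2 sit at the limit described by the limit of > 50000 nM in this assay, at which 2 of the 3 values shown sit. Going by the values given here, the one measured step, an at least 9.2-fold lower number from compound 2 to compound 3 (0.96 log units; beyond the scatter), is the only guide to what a substituent on that aromatic carbon does.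

Compound 4 `O=[N+]([O-])c1ccc(-c2noc(Cc3c[nH]c4ccccc34)n2)cc1` differs from compound 3 as follows: nitro in place of fluoro on an aromatic carbon. Among the compounds with values here, no measured step compares nitro with fluoro, so the direction is open; the step from compound 2 to compound 3 shows only that a substituent on that carbon can move the number, not what a different group would do. The estimate for compound 4 is therefore 6000 nM (1200 nM to 50000 nM) in this assay, kept near its starting point with a wide range, and the step expected is a 1.1-fold higher number from compound 3 to compound 4 (0.05 log units; within the scatter), with a real chance that this assay again returns only a limit.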

Compound 4, half-maximal inhibitory concentration: > 50000 nM
Compound 4: a limit, no number (the forecaster's own chance of this, stated with the estimate: 35%); middle value at least 8.3-fold (0.92 log units) from the limit.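

On the aromatic carbon para to a large group, nitro in place of fluoro gives an at least 9.2-fold higher number from compound 3 to compound 4 (0.96 log units; beyond the scatter) and so shows that a substituent at this carbon does not by itself yield a number: the measurable inhibition seen so far belongs to fluoro alone, not to substitution in general. The step from compound 2 to compound 4 cannot be read, as both values are limits. For the compounds shown here, compound 3 is now the only one of the four analogues with a number in this assay, and the others share one limit: the limit of > 50000 nM in this assay, at which 3 of the 4 values shown sit.

Still open, from the compounds shown here alone, is whether any other group on this carbon, such as chloro, methyl, an amine or a carboxylic acid, gives a number in this assay. With a single number in the series, no trend across substituents can yet be drawn.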